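The source may hold more compounds than are shown below. What is called first, only, known or untested is meant among the compounds shown, and "the series" means these compounds.

- compound 1 `C=C(CC)C(=O)c1ccc(OCC(=O)Nc2nc3ccccc3s2)c(Cl)c1Cl`: 1500 nM
- compound 2 `C=C(CC)C(=O)c1ccc(OCC(=O)Nc2ccc(C(=O)O)cc2)c(Cl)c1Cl`: 5000 nM
- compound 3 `C=C(CC)C(=O)c1ccc(OCC(=O)NCO[N+](=O)[O-])c(Cl)c1Cl`: 4100 nM

In a functional assay on CLL cells (Homo sapiens) for cytotoxicity, read by MTT assay, with a stated time of 48 h (on this read-out lower numbers stand for an effect already at smaller amounts and higher numbers for an effect only at larger amounts of compound), compound 3 gives 4100 nM, which places it among the higher numbers of the three. The data show a 1.2-fold lower number from compound 2 to compound 3 (0.09 log units; within the scatter), and they also show a 2.7-fold higher number from compound 1 to compound 3 (0.44 log units; beyond the scatter).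

The next compound is compound 4 `C=C(CC)C(=O)c1ccc(OCC(=O)Nc2ccc(C#N)cc2)c(Cl)c1Cl`, with 4-cyanophenyl in place of (nitrooxy)methyl on an amide-type nitrogen.

Among the measured compounds shown here, no measured step makes this exact change, so the evidence is indirect. Compound 2 also carries a substituted phenyl group, and the step already given for it, 5000 nM against compound 3, lies within the scatter. Compound 1 shows that this nitrogen substituent can matter, with a 3.3-fold higher number from compound 1 to compound 2 (0.52 log units; beyond the scatter).

Compound 4 is therefore expected to sit within the range spanned by the measured compounds, with at most a modest move towards a lower number. The expected step is a 1.5-fold lower number from compound 3 to compound 4 (0.17 log units; within the scatter). For compound 4 the estimate is 2800 nM, with an expected range of 1100 nM to 6500 nM.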

Compound 4, half-maximal effective concentration: 7800 nM
Estimate against measurement, compound 4: 2.8-fold (0.44 log units) below, outside the stated range (above it).
By their numbers in this assay, from the lowest: compound 1; then compounds 3, 2 and 4 (each within the scatter of the next).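

In this assay, cyano in place of carboxy on an aromatic carbon gives a 1.6-fold higher number from compound 2 to compound 4 (0.19 log units; within the scatter), and 4-cyanophenyl in place of (nitrooxy)methyl gives a 1.9-fold higher number from compound 3 to compound 4 (0.28 log units; within the scatter), so neither of these changes on the amide-type nitrogen separates the compounds beyond the scatter. Of the new steps, only a 5.2-fold higher number from compound 1 to compound 4 (0.72 log units; beyond the scatter) lies beyond the scatter, which leaves 1,3-benzothiazol-2-yl as the one substituent here that stands apart from the other three. Nothing available explains why this substituent differs from the others.

On these data alone, it remains open whether a plain phenyl, a 4-aminophenyl or a 1,3-benzoxazol-2-yl group on this nitrogen would give a number near that of compound 1 or near those of the other three. As far as these compounds go, all four compounds share the same core, so it is also open whether the gap would persist with a longer chain in place of the ethyl group.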